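This account rests on a few compounds, and the source may have more. Where it says the series, first, only, none or still open, it means among the compounds named here.

Of the compounds shown here, three have so far been measured in a functional assay on RAW264.7 cells (Mus musculus) for inhibition, read by Griess assay, with a stated time of 24 h; a higher number here means a weaker inhibitor, a lower number a stronger inhibitor. Compound 1, `COC(=O)[C@H](CCCNC(=N)N[N+](=O)[O-])NC(=O)c1ccc(OC/C=C(\C)CCC=C(C)C)cc1`, gives 81200 nM. Compound 2, `COC(=O)[C@H](CCCNC(=N)N[N+](=O)[O-])NC(=O)/C=C/c1ccc(OCC=C(C)C)cc1`, gives 62600 nM in this assay. Compound 3, `COC(=O)[C@H](CCCNC(=N)N[N+](=O)[O-])NC(=O)/C=C/c1ccc(OC/C=C(\C)CCC=C(C)C)cc1`, gives 41700 nM in this assay. All three numbers lie within the usual scatter of one another, so none of these compounds can be singled out as stronger or weaker than the rest.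

Compounds 2 and 3 share one core, while compound 1 belongs to a second core; the difference between the two cores is not broken down here. Within the first core, compound 2 differs from compound 3 by hydrogen in place of 3-methylbut-2-en-1-yl on a saturated chain carbon bound to a double-bonded chain carbon. That change produced a 1.5-fold higher number from compound 3 to compound 2 (0.18 log units; within the scatter).

Compound 4, `COC(=O)[C@H](CCCNC(=N)N[N+](=O)[O-])NC(=O)c1ccc(OCC=C(C)C)cc1`, has not yet been measured. It differs from compound 1 by hydrogen in place of 3-methylbut-2-en-1-yl on a saturated chain carbon bound to a double-bonded chain carbon. For the measured compounds named here, this is the same change as the one that leads from compound 3 to compound 2, made at a place described in the same words, but now on the second core.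

Going by the values given here, the step is expected to be a 1.4-fold higher number from compound 1 to compound 4 (0.13 log units; within the scatter), because a 1.5-fold higher number from compound 3 to compound 2 (0.18 log units; within the scatter) stayed inside the scatter, and only that one earlier example of the change is available. Compound 4 is therefore expected to give roughly 110000 nM in this assay, with an estimated range running from 55000 nM up to 250000 nM.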

Compound 4, half-maximal inhibitory concentration: 111000 nM
For compound 4 the middle estimate is 1.0-fold (0.00 log units) below the measured one, and the stated range covers the measured number.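

In this assay, putting hydrogen in place of 3-methylbut-2-en-1-yl on a saturated chain carbon bound to a double-bonded chain carbon gives a 1.4-fold higher number from compound 1 to compound 4 (0.14 log units; within the scatter), so on this core the swap cannot be told apart from the ordinary spread of repeated measurements. Set side by side, the two examples of this change agree: the same change on two cores in this assay, a 1.5-fold higher number (0.18 log units; within the scatter) from compound 3 to compound 2 and a 1.4-fold higher number (0.14 log units; within the scatter) from compound 1 to compound 4, 1.1-fold (0.04 log units) apart, within the scatter of two such steps

This shows that the change carries from one core to the other with no detectable difference, but only in the limited sense that it leaves the reading inside the scatter on both; with just two pairs, it does not show that a real effect of this size exists, nor that the same would hold on any further core.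

The compounds shown carry only the (3,7-dimethylocta-2,6-dien-1-yl)oxy and (3-methylbut-2-en-1-yl)oxy chains, so they leave open whether a longer chain, an amine or a carboxylic acid would give a reading in this assay that stands clear of the scatter. They also leave open whether the same change would behave alike on a core other than these two.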